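Fluoro to Methoxy on the Amide-Bearing Ring

The compounds below may be only part of what the source reports. "The series", "measured", "known", "first", "only" and "open" are said of these compounds alone.

Measured compounds:
Compound 1, `COc1ccccc1NC(=O)CCC(=O)OCCCCCCSc1ccc([N+](=O)[O-])c2nonc12`: 1610 nM
Compound 2, `O=C(CCC(=O)OCCCCCCSc1ccc([N+](=O)[O-])c2nonc12)Nc1ccc(F)cc1`: 1740 nM

Both compounds share a long ester-linked chain ending in a nitro-bearing core and differ only in the ring on the amide nitrogen. In an ADME assay on HUVEC cells (Homo sapiens) for cytotoxicity, read by MTT assay, with a stated time of 72 h (a higher number here means a weaker inhibitor, a lower number a stronger inhibitor), compound 2 gives the highest of the two numbers; its nearest neighbour is compound 1, and the step of a 1.1-fold higher number from compound 1 to compound 2 (0.03 log units; within the scatter) separates them. Going by the values given here, that change, 4-fluorophenyl in place of 2-methoxyphenyl on an amide-type nitrogen, is the only measured step so far.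

Compound 3, `COc1ccc(NC(=O)CCC(=O)OCCCCCCSc2ccc([N+](=O)[O-])c3nonc23)cc1`, is the next member. Relative to compound 2 the change is methoxy in place of fluoro on an aromatic carbon. Among the compounds with values here, the one step that bears on it is a 1.1-fold higher number from compound 1 to compound 2 (0.03 log units; within the scatter), which already placed a methoxy-bearing ring and a fluoro-bearing ring at the same position without a difference beyond the scatter. On that basis the step from compound 2 to compound 3 is expected to be a 1.0-fold lower number from compound 2 to compound 3 (0.01 log units; within the scatter) in this assay, with no direction beyond the scatter.

Compound 3 is therefore estimated at 1700 nM, within a range from 900 nM to 3400 nM.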

Compound 3, half-maximal inhibitory concentration: 1590 nM
Compound 3: middle estimate off by 1.1-fold (0.03 log units), on the high side; the measured number falls inside the stated range.
By their numbers in this assay, from the lowest: compounds 3, 1 and 2 (each within the scatter of the next).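

In this assay, methoxy in place of fluoro on an aromatic carbon, para to a large group, gives a 1.1-fold lower number from compound 2 to compound 3 (0.04 log units; within the scatter), so a direct comparison now shows that this position does not tell these two groups apart. The second new comparison, 4-methoxyphenyl in place of 2-methoxyphenyl on the amide nitrogen, gives a 1.0-fold lower number from compound 1 to compound 3 (0.01 log units; within the scatter), so with the group held as methoxy, its two placements on the ring also cannot be told apart in this assay. No measurement here accounts for why these numbers stay within the scatter of one another, and the three compounds alone cannot show whether the ring substituent matters at all in other settings.

From the compounds shown here alone, it remains open whether a different kind of group on this ring, such as an amine or a carboxylic acid, would give a number beyond the scatter. The compounds shown also leave open how a longer chain, or an amide in place of the ester, would affect the number, since all three share the same chain, the same ester and the same core.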